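From Benzoyl to Piperidinylsulfonyl on the Shared Core

The compounds below may be only part of what the source reports. "The series", "measured", "known", "first", "only" and "open" are said of these compounds alone.

Within the data shown here, compound 1 `CC1(C)Oc2ccc(C(=O)c3ccccc3)cc2[C@@H](/N=C(\NC#N)Nc2ccc(Cl)cc2)[C@@H]1O` is the weaker of the two compounds measured so far in a functional assay (aorta) with Rattus norvegicus as the target; on this read-out lower numbers stand for stronger inhibition and higher numbers for weaker inhibition: compound 1 gives 7100 nM, the highest of the two numbers. Compound 2 `CC1(C)Oc2ccc(S(=O)(=O)Nc3ccccc3)cc2[C@@H](/N=C(\NC#N)Nc2ccc(Cl)cc2)[C@@H]1O` stands nearest to it; in this assay compound 2 gives 3300 nM, and the step of a 2.2-fold lower number from compound 1 to compound 2 (0.33 log units; beyond the scatter) is a modest one. Compound 3 `CC1(C)Oc2ccc(S(=O)(=O)N3CCCCC3)cc2[C@@H](/N=C(\NC#N)Nc2ccc(Cl)cc2)[C@@H]1O` has not yet been measured. It differs from compound 1 by (piperidin-1-yl)sulfonyl in place of benzoyl on an aromatic carbon. Among the measured compounds shown here, the only measured step that bears on this change is a 2.2-fold lower number from compound 1 to compound 2 (0.33 log units; beyond the scatter), where a sulfonyl-bearing group likewise took the place of the benzoyl; that step was modest but beyond the scatter. On that basis compound 3 is expected to show a modest step to a lower number, in the direction taken by compound 2, namely a 2.0-fold lower number from compound 1 to compound 3 (0.31 log units; beyond the scatter). Compound 3 is therefore estimated at 3500 nM, with a range from 1500 nM to 8000 nM.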

Compound 3, half-maximal inhibitory concentration: 1900 nM
Compound 3: middle estimate off by 1.8-fold (0.27 log units), on the high side; low and high end bracket the measured number.
By their numbers in this assay, from the lowest: compounds 3 and 2 (each within the scatter of the next); then compound 1.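

In this assay, a second sulfonyl group at this aromatic carbon also lowers the number, with (piperidin-1-yl)sulfonyl in place of benzoyl giving a 3.7-fold lower number from compound 1 to compound 3 (0.57 log units; beyond the scatter). The earlier step had shown this only for the phenylsulfamoyl group; now piperidin-1-yl in place of anilino on the sulfonyl sulfur gives a 1.7-fold lower number from compound 2 to compound 3 (0.24 log units; within the scatter), which lies within the scatter, so the non-aromatic ring serves as well as the anilino group in this read-out. Nothing available here explains the result.

From the compounds shown here alone, it remains open how far the group on the sulfur can vary, for instance whether a small amine such as dimethylamino or a morpholine ring would keep the number at this level. Going by these compounds, it is also open whether a sulfonyl group is needed at all, which a carboxylic acid on the same aromatic carbon could help to show.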